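From compound 2 to its isomer, compound 4

The source may report more compounds than this note shows. Statements on the series, on what has been measured and on what is new or still open speak of the compounds shown alone.

Measured in a functional assay on HepG2 cells (Homo sapiens) for inhibition, read by MTT assay, with a stated time of 120 h; on this read-out higher numbers stand for weaker inhibition and lower numbers for stronger inhibition:
Compound 1 `C/C(=C\c1ccc(NC(=O)Nc2ccc(Cl)c(C(F)(F)F)c2)cc1)C(=O)NC(C)c1ccccc1` (> 50000 nM as a limit of the assay)
Compound 2 `CNC(=O)/C(C)=C/c1ccc(NC(=O)Nc2ccc(Cl)c(C(F)(F)F)c2)cc1` (44300 nM)
Compound 3 `CC(NC(=O)c1ccc(-c2ccc(NC(=O)Nc3cc(C(F)(F)F)ccc3Cl)cc2)cc1)c1ccccc1` (18400 nM)

Of the two actual numbers, compound 2 holds the higher (44300 nM) and compound 3 the lower (18400 nM). Compound 1 stands at a limit rather than a number (> 50000 nM).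

In compound 4 `CNC(=O)/C=C(\C)c1ccc(NC(=O)Nc2ccc(Cl)c(C(F)(F)F)c2)cc1`, 1-methyl-2-(methylcarbamoyl)ethenyl stands in place of 2-(methylcarbamoyl)prop-1-en-1-yl on an aromatic carbon (1-methyl-2-(methylcarbamoyl)ethenyl in place of 2-(methylcarbamoyl)prop-1-en-1-yl on an aromatic carbon), with the same atoms joined differently. Going by the values given here, the one measured step that touches this side chain is an at least 1.1-fold lower number from compound 1 to compound 2 (0.05 log units; that floor lies within the scatter), with methyl in place of 1-phenylethyl on an amide-type nitrogen. That is a different kind of change, and its floor lies within the scatter. With only an at least 1.1-fold lower number from compound 1 to compound 2 (0.05 log units; that floor lies within the scatter) to go on, no step beyond the scatter is expected in this assay in either direction. The expected step is a 1.1-fold lower number from compound 2 to compound 4 (0.04 log units; within the scatter) in this estimate. For compound 4 the estimated value is 40000 nM in a range from 17000 nM to 90000 nM as expected limits of the number.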

Compound 4, half-maximal inhibitory concentration: > 50000 nM
Compound 4: no number, only a limit (the forecaster's own chance of this, stated with the estimate: 35%); middle value at least 1.2-fold (0.09 log units) away from the limit.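

In this assay compound 4 gives > 50000 nM, which is a limit and not a number. Going by these compounds alone, with 1-methyl-2-(methylcarbamoyl)ethenyl in place of 2-(methylcarbamoyl)prop-1-en-1-yl on the aromatic carbon, the read-out shows an at least 1.1-fold higher number from compound 2 to compound 4 (0.05 log units; that floor lies within the scatter), so the same atoms joined differently give no step that can be told from the scatter, and the true size of the step stays unknown. Where the earlier step concerned only the group on the amide nitrogen, this one changes how the side chain itself is joined, and the result again ends at the top of the read-out: the limit of > 50000 nM in this assay, at which 2 of the 4 values shown sit.

On these data alone, how far the number could move at this position remains open, since neither arrangement of the chain gives a value far from that limit. A carboxylic acid in place of the methylamide, or a longer chain on the amide nitrogen, could show whether this side chain can lower the number at all.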